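The source may hold more compounds than are shown below. What is called first, only, known or untested is meant among the compounds shown, and "the series" means these compounds.

Measured compounds and their numbers in the displacement read-out:
compound 1 `CCCCCCSc1nc2ccccc2n1CC(=O)O`: 1360 nM
compound 2 `O=C(O)Cn1c(SCc2ccccc2Cl)nc2ccccc21`: 370 nM

Going by the values given here, in an assay on HEK293 cells for displacement of a labelled ligand from prostaglandin D2 receptor 2 (Homo sapiens) (on this read-out lower numbers stand for stronger inhibition and higher numbers for weaker inhibition), compound 2 gives 370 nM, the lowest of the two numbers so far; the nearest is compound 1 with 1360 nM. Among the compounds with values here, the one measured step, a 3.7-fold lower number from compound 1 to compound 2 (0.57 log units; beyond the scatter), moved the number down beyond the scatter.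

Compound 3 `Cc1ccc(CSc2nc3ccccc3n2CC(=O)O)cc1` carries the change (4-methylphenyl in place of 2-chlorophenyl on a saturated chain carbon bound to a sulfur). Within the data shown here, the only step that bears on it is a 3.7-fold lower number from compound 1 to compound 2 (0.57 log units; beyond the scatter), which replaced a pentyl chain with an aryl ring at the same place; no measured step exchanges one aryl ring for another, so the size of the move from 2-chlorophenyl to 4-methylphenyl has no direct precedent here. Compound 3 keeps an aryl ring on the saturated chain carbon bound to a sulfur, so a number near compound 2 is expected, with the step of a 1.4-fold higher number from compound 2 to compound 3 (0.13 log units; within the scatter) estimated to stay within the scatter or slightly weaker. For compound 3 the estimate in this assay is 500 nM, with a range from 200 nM to 1300 nM.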

Compound 3, half-maximal inhibitory concentration: 220 nM
Compound 3: middle estimate off by 2.3-fold (0.36 log units), on the high side, and the stated range covers the measured number.
By their numbers in this assay, from the lowest: compounds 3 and 2 (each within the scatter of the next); then compound 1.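

In this assay, going by these compounds alone, this is the first exchange of one aryl ring for another on a saturated chain carbon bound to a sulfur, and it gives a 1.7-fold lower number from compound 2 to compound 3 (0.23 log units; within the scatter), so the data do not separate 4-methylphenyl from 2-chlorophenyl at this place. Set against the pentyl of compound 1, 4-methylphenyl gives a 6.2-fold lower number from compound 1 to compound 3 (0.79 log units; beyond the scatter), and with a 3.7-fold lower number from compound 1 to compound 2 (0.57 log units; beyond the scatter) alongside it, two different aryl rings now each stand apart from the pentyl group. Nothing available gives a reason for either step.

Still open is whether the methyl or the chlorine matters at all, as plain phenyl is not among the compounds shown, and 4-methylphenyl and 2-chlorophenyl differ in both the group and its place on the ring. Also open, on these data alone, is how a ring carrying an amine or a carboxylic acid would read here.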